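This account rests on a few compounds, and the source may have more. Where it says the series, first, only, none or still open, it means among the compounds named here.

Measured so far:
compound 1, `COC(=O)c1ccc(NC(=O)Nc2cc(C)nc3ccccc23)cc1`: 1200 nM
compound 2, `Cc1cc(NC(=O)Nc2cccc(OC(F)(F)F)c2)c2ccccc2n1`: 600 nM

In a physicochemical assay for solubility, at pH 7.4 (a higher number here means a more soluble compound, a lower number a less soluble compound), compound 1 gives 1200 nM and compound 2 gives 600 nM; the two values lie within the scatter of each other, so neither stands apart. Compound 3, `COc1ccc(NC(=O)Nc2cc(C)nc3ccccc23)cc1`, has not been measured in this assay. It differs from compound 1 in one place: methoxy in place of methoxycarbonyl on an aromatic carbon. Among the compounds with values here, no measured pair shows this change, so its size is open; a step within the scatter, or a small rise, is expected. For compound 3 the estimated solubility is 1500 nM, with an expected range from 600 nM to 4000 nM. That estimate is expected to mean a step of a 1.3-fold higher number from compound 1 to compound 3 (0.10 log units; within the scatter).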

Compound 3, solubility: 19800 nM
Beside the measured number, compound 3's estimate is 13-fold (1.12 log units) below it; the measured number lies above the stated range.
By their numbers in this assay, from the lowest: compounds 2 and 1 (each within the scatter of the next); then compound 3.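

In this assay, this place on the aromatic ring is far from neutral: methoxy in place of methoxycarbonyl gives a 17-fold higher number from compound 1 to compound 3 (1.22 log units; beyond the scatter) as a large step from one substitution. Within the data shown here, the earlier compounds held no pair differing in one place, so this is the first size of a single change. No measurement at hand accounts for the step.

Still open, as far as these compounds go, is whether the step follows the loss of methoxycarbonyl or the entry of methoxy. A carboxylic acid, an amine or a longer chain at this place would show how far the number moves with the group.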